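Swapping Fluoro for Methyl on a Shared Amide Scaffold

This account rests on a few compounds, and the source may have more. Where it says the series, first, only, none or still open, it means among the compounds named here.

Three measured compounds share one large amide scaffold and differ in two places. Compound 2 `COc1cc2c(Oc3ccc(NC(=O)c4cn(-c5ccccc5F)nn4)cc3F)ccnc2cc1OCCCN1CCCCC1` gives 290 nM in a functional assay on HT-29 cells (Homo sapiens) for cytotoxicity, read by MTT assay, with a stated time of 72 h; on this read-out higher numbers stand for weaker inhibition and lower numbers for stronger inhibition. Compound 1 `COc1cc2c(Oc3ccc(NC(=O)c4cn(-c5ccccc5C)nn4)cc3F)ccnc2cc1OCCCN1CCCCC1` differs from compound 2 by methyl in place of fluoro on an aromatic carbon, and in this assay compound 1 gives 1340 nM, so that a 4.6-fold higher number from compound 2 to compound 1 (0.66 log units; beyond the scatter). Compound 3 `COc1cc2c(Oc3ccc(NC(=O)c4cn(-c5ccccc5F)nn4)cc3F)ccnc2cc1OCCCN1CCN(C)CC1` differs from compound 2 in its core by 4-methylpiperazin-1-yl in place of piperidin-1-yl on a saturated chain carbon, three bonds along the chain from an oxygen on an aromatic ring; in this assay compound 3 gives 300 nM, which means a 1.0-fold higher number from compound 2 to compound 3 (0.01 log units; within the scatter). Compound 4 `COc1cc2c(Oc3ccc(NC(=O)c4cn(-c5ccccc5C)nn4)cc3F)ccnc2cc1OCCCN1CCN(C)CC1` is not yet measured and differs from compound 3 by methyl in place of fluoro on an aromatic carbon. The place of this change reads the same as the place of the change from compound 2 to compound 1, so it is the same change, made here on the core of compound 3, and it occurs twice in this set. The expectation rests on the measured step of a 4.6-fold higher number from compound 2 to compound 1 (0.66 log units; beyond the scatter), and on the core swap having given only a 1.0-fold higher number from compound 2 to compound 3 (0.01 log units; within the scatter). The step from compound 3 to compound 4 is therefore expected to be a 4.7-fold higher number from compound 3 to compound 4 (0.67 log units; beyond the scatter). Compound 4 is estimated at 1400 nM in this assay, most likely between 700 nM and 2800 nM.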

Compound 4, half-maximal inhibitory concentration: 1430 nM
Estimate against measurement, compound 4: 1.0-fold (0.01 log units) below, within the range that was stated.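

In this assay, methyl in place of fluoro on the aromatic carbon gives a 4.8-fold higher number from compound 3 to compound 4 (0.68 log units; beyond the scatter), and this step on the piperazine-bearing core matches the one measured on the piperidine-bearing core: the same change on two cores in this assay, a 4.6-fold higher number (0.66 log units; beyond the scatter) from compound 2 to compound 1 and a 4.8-fold higher number (0.68 log units; beyond the scatter) from compound 3 to compound 4, 1.0-fold (0.01 log units) apart, within the scatter of two such steps

The other swap, 4-methylpiperazin-1-yl in place of piperidin-1-yl, now read with methyl on the aromatic ring, gives a 1.1-fold higher number from compound 1 to compound 4 (0.03 log units; within the scatter), so the two groups cannot be told apart here with either fluoro or methyl present: the same change on two cores in this assay, a 1.0-fold higher number (0.01 log units; within the scatter) from compound 2 to compound 3 and a 1.1-fold higher number (0.03 log units; within the scatter) from compound 1 to compound 4, 1.0-fold (0.01 log units) apart, within the scatter of two such steps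

Together these steps show that the two changes carry over between these cores in this one cell assay, but they do not show that the same would hold on any other core or in any other assay, and the numbers alone do not explain why methyl gives the higher value.

The compounds shown leave open how a chloro or methoxy group would compare with fluoro and methyl at this place on the aromatic ring. They also leave open whether a morpholin-4-yl group in place of piperidin-1-yl would match the two amines compared here.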